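A few compounds are considered here, and "the series" means these few. Any claim that something is new, unique, unknown or untested is made for them only; others in the source may bear on it.

Compound 2 `Nc1ccc(-c2nc3ccccc3s2)cc1I` carries an iodo group on the shared core. In a physicochemical assay for lipophilicity, at pH 7.4 (a lower number here means a more polar compound, a higher number a more lipophilic compound), compound 2 gives > 2.7, which is a limit of the assay and not a number. Its exact position is therefore unknown. Compound 3 `Nc1ccc(-c2nc3ccccc3s2)cc1Br` has not yet been measured, and it differs from compound 2 at this one place: bromo in place of iodo on an aromatic carbon.

The closest comparison comes from compound 1 `Nc1ccc(-c2nc3ccccc3s2)cc1Cl`, which carries chloro at that same place. In this assay compound 1 gives > 3.2, and this too is a limit. Going by the values given here, the only measured step that bears on the change is a step that the two limits leave unreadable from compound 1 to compound 2. It offers neither a size nor a direction, so no step beyond the usual scatter is expected on this evidence. The estimated step is a step that the limit leaves unreadable from compound 2 to compound 3. With so little to go on, the range has to stay wide, and a further limit is a likely result. For compound 3 the estimated value is 3.6, with an expected range from 3 to 4.3.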

Compound 3, distribution coefficient: > 2.8
Compound 3 ended at the assay's limit; the forecaster's own chance of this, stated with the estimate: 70%; the middle value lies beyond the limit too.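

In this assay compound 3 gives > 2.8, which is a limit of the assay and not a number. Compound 1 and compound 2 also stand at limits, so the steps from each of them to compound 3 cannot be read. The compounds shown leave open where their true values lie, and whether exchanging chloro, bromo and iodo shifts the distribution coefficient at all.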